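Exchanging a Group at the Carbonyl of Compound 2

The source may report more compounds than this note shows. Statements on the series, on what has been measured and on what is new or still open speak of the compounds shown alone.

A medicine has to survive the liver long enough to act, and an ADME assay on microsomes from liver (Rattus norvegicus, strain Crj;CD(SD)) for metabolic stability, read by LC-MS, using NADPH, with a stated time of 30 min, tested at 0.1 uM (a higher number here means that more of the compound is left, a lower number that less of the compound is left), offers an early look at how well a compound does so. In this assay compound 1 (`COCC1=C[C@@](C)(c2cc(NC(=O)c3ccc(C#N)cn3)ccc2F)N=C(N)O1`) gives 61% and compound 2 (`C[C@@]1(c2cc(NC(=O)c3cnc(OCF)cn3)ccc2F)C=C(CF)OC(N)=N1`) gives 52% as the share left. These two numbers lie within the usual scatter of each other, so compound 2 cannot be told apart from compound 1 on what is known so far.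

Compound 3 (`C[C@@]1(c2cc(NC(=O)c3ncc(C#N)cc3Cl)ccc2F)C=C(CF)OC(N)=N1`) carries 3-chloro-5-cyanopyridin-2-yl in place of the 5-(fluoromethoxy)pyrazin-2-yl of compound 2 on a carbonyl carbon (3-chloro-5-cyanopyridin-2-yl in place of 5-(fluoromethoxy)pyrazin-2-yl on a carbonyl carbon). Going by the values given here, no two measured compounds differ in one place only, so no measured step shows what such an exchange does. Among the compounds with values here, with compound 1 at 61% and compound 2 at 52% as the only guides, no change beyond the scatter is expected in this assay for this exchange. The expected step is a number 4 percentage points higher from compound 2 to compound 3 (within the scatter) and it stays inside the scatter. With so few numbers, the range has to stay wide. The estimate for compound 3 is 56% (range 38% to 74%).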

Compound 3, percent of the compound remaining: 49%
Compound 3: the middle estimate sits 7 percentage points above what was measured; the measured number falls inside the stated range.
By their numbers in this assay, from the lowest: compounds 3, 2 and 1 (each within the scatter of the next, the first and the last beyond it).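

Going by these compounds alone, this is the first exchange at this place, on a carbonyl carbon whose other neighbour is an amide-type nitrogen, that can be read directly, and in this assay it gives a number 3 percentage points lower from compound 2 to compound 3 (within the scatter) and so stays inside the usual scatter. The two groups differ in what they carry: 3-chloro-5-cyanopyridin-2-yl brings a chlorine and a triple bond outside the ring, whereas 5-(fluoromethoxy)pyrazin-2-yl brings a fluorine, an oxygen and a second ring nitrogen, yet this read-out does not separate the two compounds. No supporting measurement is available that would explain this result.

One exchange between two aromatic rings of equal heavy-atom count cannot show how much freedom this place allows, and it also cannot show whether the chlorine and the nitrile would give the same result if each were present alone. A group of a quite different kind on the same carbonyl carbon, such as an amine or a ring carrying a carboxylic acid, might yet move the share of compound left beyond the scatter, and the compounds shown leave that question open.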